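Shortening the linker on the saturated ring carbon

The compounds below may be only part of what the source reports. "The series", "measured", "known", "first", "only" and "open" are said of these compounds alone.

Compound 1 `CCC(=O)NCC1CCCN(S(=O)(=O)c2ccc(F)cc2)C1` gives 10 mg/kg in a functional assay on the whole organism with Mus musculus as the target, with a stated time of 30 min (on this read-out higher numbers stand for an effect only at larger amounts of compound and lower numbers for an effect already at smaller amounts), the highest of the two numbers recorded. Compound 2 `CC(=O)NC1CCN(S(=O)(=O)c2ccc(F)cc2)CC1` gives 0.01 mg/kg in this assay, a gap from compound 1 that lies far beyond the usual scatter. Compound 3 `CCC(=O)NC1CCCN(S(=O)(=O)c2ccc(F)cc2)C1` has not been measured in this assay. It differs from compound 1 by propanoylamino in place of (propanoylamino)methyl on a saturated ring carbon. Among the measured compounds shown here, no measured pair maps this change; what is known is only that compound 2 gives 0.01 mg/kg. Compound 3 is therefore expected to move toward lower numbers, with the step of a 33-fold lower number from compound 1 to compound 3 (1.52 log units; beyond the scatter) going beyond the scatter. The estimate for compound 3 in this assay is 0.3 mg/kg, within 0.03 mg/kg to 3 mg/kg.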

Compound 3, minimum effective dose: 1 mg/kg
The estimate for compound 3 lay 3.3-fold (0.52 log units) below the measured number, within the range that was stated.
By their numbers in this assay, from the lowest: compound 2; then compound 3; then compound 1.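

In this assay, among the compounds shown here, propanoylamino in place of (propanoylamino)methyl on a saturated ring carbon gives a 10-fold lower number from compound 1 to compound 3 (1.00 log units; beyond the scatter) and is the first single-place change that can be read. The read-out at this position therefore responds to the linker alone, with the propanoyl amide and the rest of the core kept. Nothing on hand gives a reason for this step. Open, as far as these compounds go, is how a longer chain on the same ring carbon, or an amine in place of the amide, would read in this assay.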